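Alkyne removed: cyclopropylethynyl to fluorophenyl on the core

The source may report more compounds than this note shows. Statements on the series, on what has been measured and on what is new or still open speak of the compounds shown alone.

Compound 1 `Nc1ncnn2c([C@@H]3O[C@H](CO)[C@@H](O)[C@H]3O)cc(C#CC3CC3)c12` gives 80 nM in a functional assay on NCI-H460 cells (Homo sapiens) for antiproliferative activity, with a stated time of 72 h (a higher number here means a weaker inhibitor, a lower number a stronger inhibitor), and stands lowest of the three numbers shown. Compound 3 `Nc1ncnn2c([C@@H]3O[C@H](CO)[C@@H](O)[C@H]3O)cc(C#Cc3ccccc3)c12` gives 38500 nM, and compound 2 `Nc1ncnn2c([C@@H]3O[C@H](CO)[C@@H](O)[C@H]3O)cc(C#Cc3ccc(F)cc3)c12` gives 79400 nM. Going by the values given here, the steps that bear on the change are a 480-fold higher number from compound 1 to compound 3 (2.68 log units; beyond the scatter) and a 990-fold higher number from compound 1 to compound 2 (3.00 log units; beyond the scatter); between the two aryl alkynes the step of a 2.1-fold lower number from compound 2 to compound 3 (0.31 log units; beyond the scatter) is modest. Compound 4 `Nc1ncnn2c([C@@H]3O[C@H](CO)[C@@H](O)[C@H]3O)cc(-c3ccc(F)cc3)c12` differs from compound 1 by 4-fluorophenyl in place of 2-cyclopropylethynyl on an aromatic carbon. Among the compounds with values here, no measured compound carries an aromatic ring directly on the core without the triple bond, so that part of the change is not covered by the data. A large step toward a weaker inhibitor is nevertheless expected; the expected step is a 250-fold higher number from compound 1 to compound 4 (2.40 log units; beyond the scatter). Compound 4 is estimated at 20000 nM, with a range from 2000 nM to 150000 nM.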

Compound 4, half-maximal inhibitory concentration: 55500 nM
For compound 4 the middle estimate is 2.8-fold (0.44 log units) below the measured one, within the range that was stated.
By their numbers in this assay, from the lowest: compound 1; then compounds 3, 4 and 2 (each within the scatter of the next, the first and the last beyond it).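

Setting 4-fluorophenyl directly on the aromatic carbon, with no triple bond, still gives a 690-fold higher number from compound 1 to compound 4 (2.84 log units; beyond the scatter) in this assay, so a weak number at this position does not depend on the triple bond. Against the aryl alkynes, the data show a 1.4-fold higher number from compound 3 to compound 4 (0.16 log units; within the scatter) and a 1.4-fold lower number from compound 2 to compound 4 (0.16 log units; within the scatter), both within the scatter, leaving 2-cyclopropylethynyl in compound 1 alone at the low end. Nothing at hand explains this separation.

The compounds shown leave open whether the low number of compound 1 needs the three-membered ring, the triple bond or both. A cyclopropyl group directly on that aromatic carbon, or a triple bond carrying a longer alkyl chain, would help separate these.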